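Shortening the alkyne substituent on the pyrimidinedione core

The source may report more compounds than this note shows. Statements on the series, on what has been measured and on what is new or still open speak of the compounds shown alone.

Three analogues of a shared core have been measured in a functional assay on L1210 cells (Mus musculus); on this read-out lower numbers stand for stronger inhibition and higher numbers for weaker inhibition. Compound 1 `CC(C)(C)C#Cc1cn([C@H]2C[C@H](O)[C@@H](CO)O2)c(=O)[nH]c1=O` gives 287 ug/mL. Compound 2 `CCCCC#Cc1cn([C@H]2C[C@H](O)[C@@H](CO)O2)c(=O)[nH]c1=O` gives 1000 ug/mL, a change described by a 3.5-fold higher number from compound 1 to compound 2 (0.54 log units; beyond the scatter). Compound 3 `CC#CCc1cn([C@H]2C[C@H](O)[C@@H](CO)O2)c(=O)[nH]c1=O` reaches only the limit of the assay, > 1000 ug/mL, so that the limit of > 1000 ug/mL in this assay, at which 1 of the 3 values shown sits, applies and no number is known for it. Compound 3 thus stands at the weak end of the three, with an at least 3.4-fold higher number from compound 1 to compound 3 (0.54 log units; beyond the scatter) and a number no lower from compound 2 to compound 3 (the limit leaves the size open) leading to it.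

Compound 4 `CC#Cc1cn([C@H]2C[C@H](O)[C@@H](CO)O2)c(=O)[nH]c1=O` differs from compound 3 as follows: prop-1-yn-1-yl in place of but-2-yn-1-yl on an aromatic carbon. The change returns the triple bond to the position it holds in compound 1 and compound 2, both of which gave numbers rather than limits. The two steps that bear on it, an at least 3.4-fold higher number from compound 1 to compound 3 (0.54 log units; beyond the scatter) and a number no lower from compound 2 to compound 3 (the limit leaves the size open), point to a lower number for compound 4 than for compound 3, though the limit leaves the size open. The estimated step is an at least 2.0-fold lower number from compound 3 to compound 4 (0.30 log units; that floor lies within the scatter). For compound 4 a value of about 500 ug/mL is expected in this assay, between 150 ug/mL and 1500 ug/mL.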

Compound 4, concentration for 50% inhibition: 164 ug/mL
Compound 4: middle estimate off by 3.0-fold (0.48 log units), on the high side; measured number inside the range.
By their numbers in this assay, from the lowest: compounds 4 and 1 (each within the scatter of the next); then compound 2.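

Prop-1-yn-1-yl in place of but-2-yn-1-yl gives an at least 6.0-fold lower number from compound 3 to compound 4 (0.78 log units; beyond the scatter), so on this aromatic carbon the position of the triple bond within the chain matters in this assay. Compound 3 stands at a limit, so the size of that step is only a floor: the limit of > 1000 ug/mL in this assay, at which 1 of the 4 values shown sits. Among the groups with the triple bond on the aromatic carbon, length does not order the results simply: the butyl chain stands apart at a 6.1-fold lower number from compound 2 to compound 4 (0.79 log units; beyond the scatter), whereas methyl and tert-butyl cannot be separated at a 1.8-fold lower number from compound 1 to compound 4 (0.24 log units; within the scatter).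

The compounds shown leave open how an amine or a hydroxymethyl group on the triple-bonded carbon would read in this assay. They also leave open whether the triple bond is needed at all, which an ethyl or a propyl group on the aromatic carbon would test.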